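The compounds below may be only part of what the source reports. "The series", "measured", "known", "first", "only" and "open" are said of these compounds alone.

Three compounds have been measured in a functional assay on A549 cells (Homo sapiens) for antiproliferative activity, read by MTT assay, with a stated time of 48 h; a higher number here means a weaker inhibitor, a lower number a stronger inhibitor:

Compound 1 `CCN(CC)CCCCOc1c(OCc2ccccc2)cc2oc(-c3ccccc3)cc(=O)c2c1O` gives 1800 nM.
Compound 2 `CCN(CC)CCCOc1c(OC)cc2oc(-c3ccccc3)cc(=O)c2c1O` gives 4900 nM.
Compound 3 `CN(C)CCCOc1c(OCc2ccccc2)cc2oc(-c3ccccc3)cc(=O)c2c1O` gives 2600 nM.

Among these three, compound 2 shows the highest number. Its gap to compound 3 is within the scatter, so the two cannot be ranked against each other, while its gap to compound 1 lies beyond the scatter, so compound 1 is the stronger inhibitor of that pair. Within the data shown here, compound 2 differs from compound 1 in two places at once, so no single step links them.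

The compound not yet measured is compound 4 `COc1cc2oc(-c3ccccc3)cc(=O)c2c(O)c1OCCCCN1CCCCC1`. It differs from compound 2 only at the end of the chain: (piperidin-1-yl)methyl in place of diethylamino on a saturated chain carbon, three bonds along the chain from an oxygen on an aromatic ring.

Among the measured compounds shown here, only one measured step changes the amine at this position: a 1.4-fold higher number from compound 1 to compound 3 (0.16 log units; within the scatter). That step swaps one small amine for another and leaves the number essentially where it was. The change from compound 2 to compound 4 is of the same kind, an exchange of one saturated amine for another, so a step within the scatter is expected, with no clear direction.

The expected result for compound 4 is therefore 4000 nM, between 1500 nM and 10000 nM, which amounts to a step of a 1.2-fold lower number from compound 2 to compound 4 (0.09 log units; within the scatter).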

Compound 4, half-maximal inhibitory concentration: 34000 nM
The estimate for compound 4 lay 8.5-fold (0.93 log units) below the measured number; the measured number lies above the stated range.
By their numbers in this assay, from the lowest: compounds 1, 3 and 2 (each within the scatter of the next, the first and the last beyond it); then compound 4.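

In this assay, the end of this chain turns out not to be a silent place for exchanging one saturated amine for another: a 6.9-fold higher number from compound 2 to compound 4 (0.84 log units; beyond the scatter) lies beyond the scatter, whereas a 1.4-fold higher number from compound 1 to compound 3 (0.16 log units; within the scatter) stays within it. The two steps are not the same kind of change, however, since the earlier one swaps open-chain amines, while the new one brings in a six-membered non-aromatic ring. Cut one bond further out, the new step also reads as 3-(diethylamino)propyl to 4-(piperidin-1-yl)butyl, so the ring and the longer chain arrive together, and these two compounds cannot tell which of them accounts for the higher number.

A 3-(piperidin-1-yl)propyl chain or a 4-(diethylamino)butyl chain on the core of compound 2 would separate the ring from the chain length, and a morpholine ring at the chain end would show whether other ring amines behave like piperidine. No measurement shown here gives an explanation for this result.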